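Sulfo for carboxy in two aortic thromboxane antagonist pairs

A few compounds are considered here, and "the series" means these few. Any claim that something is new, unique, unknown or untested is made for them only; others in the source may bear on it.

Compound 1 `CC(C)c1ccc2c(CCCCCS(=O)(=O)Nc3ccccc3)cc(C(=O)O)c-2cc1` and compound 2 `CC(C)c1ccc2c(CCCCCS(=O)(=O)Nc3ccccc3)cc(S(=O)(=O)O)c-2cc1` share one core and differ by sulfo in place of carboxy on an aromatic carbon. In a functional assay on thoracic aorta for antagonist activity at thromboxane A2 receptor (Rattus norvegicus) (a lower number here means a stronger inhibitor, a higher number a weaker inhibitor), compound 1 gives 1500 nM. In this assay compound 2 gives 1400 nM. The step of a 1.1-fold lower number from compound 1 to compound 2 (0.03 log units; within the scatter) lies within the scatter, so the two values show no separation. Compound 3 `CC(C)c1ccc2c(CCCC(=O)NS(=O)(=O)c3ccccc3)cc(C(=O)O)c-2cc1` carries another core; its difference from compound 1 is not broken down here. In this assay compound 3 reaches only a limit of the assay, > 100000 nM, not a number; see (the limit of > 100000 nM in this assay, at which 1 of the 3 values shown sits). Compound 4 `CC(C)c1ccc2c(CCCC(=O)NS(=O)(=O)c3ccccc3)cc(S(=O)(=O)O)c-2cc1` differs from compound 3 by sulfo in place of carboxy on an aromatic carbon, at a place described in the same words as for the first pair. The expectation for compound 4 rests on compound 1 and compound 2, whose step a 1.1-fold lower number from compound 1 to compound 2 (0.03 log units; within the scatter) is within the scatter. Compound 4 is therefore expected to show a step that the limit leaves unreadable from compound 3 to compound 4. The estimate for compound 4 is 150000 nM, most likely again reported only as a limit.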

Compound 4, half-maximal inhibitory concentration: 65000 nM
Beside the measured number, compound 4's estimate is 2.3-fold (0.36 log units) above it, within the range that was stated.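

In this assay the exchange on the core of compound 3 gives an at least 1.5-fold lower number from compound 3 to compound 4 (0.18 log units; that floor lies within the scatter), so sulfo in place of carboxy carries no visible penalty to this second core. Set beside the first pair, the two steps read: the same change on two cores in this assay, a 1.1-fold lower number (0.03 log units; within the scatter) from compound 1 to compound 2 and an at least 1.5-fold lower number (0.18 log units; that floor lies within the scatter) from compound 3 to compound 4; the limit leaves it open whether they differ. What remains unread is the true size of the step on the core of compound 3, whose carboxy member stands only at a limit of the assay: the limit of > 100000 nM in this assay, at which 1 of the 4 values shown sits.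

The compounds shown leave open whether a tetrazole or a phosphonic acid on the same aromatic carbon would behave like sulfo and carboxy. They also leave open what a longer chain would do on the core of compound 3.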